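Replacing 3-hydroxyphenyl with 4-methylphenyl on an amide-type nitrogen

A few compounds are considered here, and "the series" means these few. Any claim that something is new, unique, unknown or untested is made for them only; others in the source may bear on it.

Of the compounds shown here, two with closely related structures have been tested so far in a functional assay on HepG2 cells (Homo sapiens) for cytotoxicity, read by CCK-8 assay; a lower number here means a stronger inhibitor, a higher number a weaker inhibitor. Compound 1 (`O=C(Nc1ccc(O)cc1)c1ncc(-c2ccc(F)cc2)o1`) gives > 30000 nM, which is a limit of the assay and not a number. Compound 2 (`O=C(Nc1cccc(O)c1)c1ncc(-c2ccccc2)o1`) gives > 30000 nM, which is also only a limit. Neither compound therefore has an exact value, and the overall picture is simple: the limit of > 30000 nM in this assay, at which 2 of the 2 values shown sit.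

Compound 3 (`Cc1ccc(NC(=O)c2ncc(-c3ccccc3)o2)cc1`) has not yet been measured. It carries 4-methylphenyl in place of 3-hydroxyphenyl on an amide-type nitrogen. Among the measured compounds shown here, no two measured compounds differ in only one place, so the data show no direct precedent for the size of this change.

The expectation rests on compound 2 and its limit of > 30000 nM. The expected change, a number no higher from compound 2 to compound 3 (the limit leaves the size open), is estimated to stay within the usual scatter, with no direction favoured. Another result reported only as a limit is also expected to be more likely than not. For compound 3, the estimate is 30000 nM, with an expected range from 10000 nM to 60000 nM.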

Compound 3, half-maximal inhibitory concentration: > 30000 nM
Compound 3 was reported as a limit; the forecaster's own chance of this, stated with the estimate: 65%; the middle value sits exactly at the limit.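

Compound 2 and compound 3 are both reported in this assay only as limits and not as numbers, so the step between them cannot be read. The compounds shown leave open which change to the structure, if any, would give a measurable value, as every result so far is the same: the limit of > 30000 nM in this assay, at which 3 of the 3 values shown sit.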